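The source may hold more compounds than are shown below. What is called first, only, known or untested is meant among the compounds shown, and "the series" means these compounds.

Three compounds built on the same core, differing only in one group on the outer ring, have been measured in an assay on HEK293 cells for agonist activity at transient receptor potential cation channel subfamily M member 8 (Homo sapiens), read by fluorescence and calcium flux, with a stated time of 15 min; on this read-out higher numbers stand for an effect only at larger amounts of compound and lower numbers for an effect already at smaller amounts. Compound 1 `CCN(Cc1cccs1)C(=O)COc1ccc(F)cc1` gives 422 nM. Compound 2 `CCN(Cc1cccs1)C(=O)COc1ccc(C(C)C)cc1` gives 397 nM. Compound 3 `CCN(Cc1cccs1)C(=O)COc1ccc(Cl)cc1` gives 39 nM, the lowest of the three numbers, with compound 2 the nearest and compound 1 the furthest. Compound 4 `CCN(Cc1cccs1)C(=O)COc1ccc(OC)cc1` is not yet measured and carries methoxy in place of chloro on an aromatic carbon. Within the data shown here, no measured compound carries methoxy, so the expectation rests on the two steps that lead into chloro: an 11-fold lower number from compound 1 to compound 3 (1.03 log units; beyond the scatter) and a 10-fold lower number from compound 2 to compound 3 (1.01 log units; beyond the scatter). Because a 10-fold lower number from compound 2 to compound 3 (1.01 log units; beyond the scatter) and an 11-fold lower number from compound 1 to compound 3 (1.03 log units; beyond the scatter) were both large, moving away from chloro is expected to raise the number again, with an expected step of a 7.7-fold higher number from compound 3 to compound 4 (0.89 log units; beyond the scatter). For compound 4 the estimate is 300 nM, within a range from 80 nM to 1200 nM.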

Compound 4, half-maximal effective concentration: 120 nM
Beside the measured number, compound 4's estimate is 2.5-fold (0.40 log units) above it; measured number inside the range.
By their numbers in this assay, from the lowest: compound 3; then compound 4; then compounds 2 and 1 (each within the scatter of the next).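

With a 3.1-fold higher number from compound 3 to compound 4 (0.49 log units; beyond the scatter) on one side, and a 3.3-fold lower number from compound 2 to compound 4 (0.52 log units; beyond the scatter) and a 3.5-fold lower number from compound 1 to compound 4 (0.55 log units; beyond the scatter) on the other, methoxy falls between chloro and the other two groups at this position. The position therefore no longer splits simply into chloro against everything else, since an intermediate result is possible here. Nothing available explains why these groups differ. Still open, on these data alone, is how an amine, a carboxylic acid or a bromo group would compare at this position. Also open, as far as these compounds go, is whether the same order would hold with a change elsewhere on the shared core.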